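Shortening the alkoxy chain: from compound 2 to compound 3

The source may hold more compounds than are shown below. What is called first, only, known or untested is meant among the compounds shown, and "the series" means these compounds.

Among the measured compounds shown here, compound 2 `CCCOc1ccc(/C=C\c2cc(OC)c(OC)c(OC)c2)cc1` gives the highest of the two numbers so far in a functional assay on A549 cells (Homo sapiens) for cytotoxicity (a higher number here means that more compound is needed for the effect, a lower number that less compound is needed), at 3.9 uM. Its nearest neighbour is compound 1 `COc1cc(/C=C\c2ccc(SC)cc2)cc(OC)c1OC`, which in this assay gives 1.9 uM. For the measured compounds named here, the only measured step, a 2.1-fold higher number from compound 1 to compound 2 (0.31 log units; beyond the scatter), is modest but beyond the scatter.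

Compound 3 `CCOc1ccc(/C=C\c2cc(OC)c(OC)c(OC)c2)cc1` is not yet measured. Its difference from compound 2 is hydrogen in place of methyl on a saturated chain carbon, two bonds along the chain from an oxygen on an aromatic ring. Going by the values given here, no measured step alters only the length of such a chain; the single known step, a 2.1-fold higher number from compound 1 to compound 2 (0.31 log units; beyond the scatter), concerns a different kind of replacement and offers no direct guide. With nothing to point in either direction, no step beyond the scatter is expected for compound 3 in this assay. The estimate for compound 3 in this assay is 3 uM, with a range from 1.2 uM to 7.5 uM. The step this estimate implies, a 1.3-fold lower number from compound 2 to compound 3 (0.11 log units; within the scatter), is expected to stay within the scatter.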

Compound 3, concentration for half-maximal effect: 1.6 uM
For compound 3 the middle estimate is 1.9-fold (0.27 log units) above the measured one; the range from low to high includes it.
By their numbers in this assay, from the lowest: compounds 3 and 1 (each within the scatter of the next); then compound 2.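

In this assay, among the compounds shown here, the length of the alkoxy chain matters at this position: going from propoxy to ethoxy gives a 2.4-fold lower number from compound 2 to compound 3 (0.39 log units; beyond the scatter) and is the first step that changes the chain alone, modest in size but beyond the scatter. The comparison with methylsulfanyl also changes with the chain, since a 1.2-fold lower number from compound 1 to compound 3 (0.07 log units; within the scatter) leaves ethoxy and methylsulfanyl within the scatter of each other, while a 2.1-fold higher number from compound 1 to compound 2 (0.31 log units; beyond the scatter) separates propoxy from methylsulfanyl. Nothing at hand speaks to the origin of these steps.

On these data alone, two chain lengths define no trend, so the effect of a butoxy or methoxy group on the same aromatic carbon remains open. Also open, as far as these compounds go, is whether a group without the chain oxygen, such as an amine, would stay level with ethoxy and methylsulfanyl.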